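The source may report more compounds than this note shows. Statements on the series, on what has been measured and on what is new or still open speak of the compounds shown alone.

Measured in a functional assay on A549 cells (Homo sapiens) for cytotoxicity, read by MTT assay, with a stated time of 72 h; a higher number here means a weaker inhibitor, a lower number a stronger inhibitor:
- compound 1 `COc1cc2c(c(OC)c1OC)-c1cc3cc(CO)oc3cc1C(O)CC2`: 16 nM
- compound 2 `COc1cc2c(c(OC)c1OC)-c1cc3cc(C(C)O)oc3cc1C(O)CC2`: 80 nM

Compound 2 holds the higher of the two numbers. Compound 3 `COc1cc2c(c(OC)c1OC)-c1cc3cc(CCO)oc3cc1C(O)CC2` has the same atoms joined differently: 2-hydroxyethyl in place of 1-hydroxyethyl on an aromatic carbon, with 2-hydroxyethyl in place of 1-hydroxyethyl on an aromatic carbon. Among the compounds with values here, one measured step bears on this, the modest 5.0-fold higher number from compound 1 to compound 2 (0.70 log units; beyond the scatter), which came with methyl in place of hydrogen on the saturated chain carbon. Compound 3 has no methyl there, so a modest move back towards a lower number is expected in this assay, probably not the full way. The expected change is a 2.5-fold lower number from compound 2 to compound 3 (0.40 log units; beyond the scatter). For compound 3 the estimated value is 32 nM, with an expected range of 10 nM to 100 nM.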

Compound 3, half-maximal inhibitory concentration: 400 nM
Beside the measured number, compound 3's estimate is 13-fold (1.10 log units) below it; measured number outside the range, above it.
By their numbers in this assay, from the lowest: compound 1; then compound 2; then compound 3.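

In this assay, the position next to the ring oxygen responds to how the same atoms are joined: 2-hydroxyethyl in place of 1-hydroxyethyl gives a 5.0-fold higher number from compound 2 to compound 3 (0.70 log units; beyond the scatter), with no change in atom count. Against hydroxymethyl, the straight chain weighs more than the branched one, with a 25-fold higher number from compound 1 to compound 3 (1.40 log units; beyond the scatter) beside a 5.0-fold higher number from compound 1 to compound 2 (0.70 log units; beyond the scatter), leaving compound 1 lowest of the three. No evidence here accounts for this order. As far as these compounds go, whether an amine or a carboxylic acid at this position would stay near hydroxymethyl remains open, as does whether a longer chain ending in hydroxy would raise the number further.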